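A Chloro Substituent Tested on Two Related Compounds

This account rests on a few compounds, and the source may have more. Where it says the series, first, only, none or still open, it means among the compounds named here.

Compound 1 `O=C(Nc1cc(C(F)(F)F)cc(C(F)(F)F)c1)c1ccc(-c2ccccc2)cc1O` was examined in a functional assay on HL-60 cells (Homo sapiens) for cytotoxicity, read by luminescence and CellTiter-Glo, with a stated time of 3 days (a higher number here means a weaker inhibitor, a lower number a stronger inhibitor), and gave 1140 nM. Compound 2 `O=C(Nc1ccc(OC(F)(F)F)cc1)c1cc(F)ccc1O` gave 850 nM in this assay, and compound 3 `O=C(Nc1ccc(OC(F)(F)F)c(Cl)c1)c1cc(F)ccc1O` gave 550 nM. The difference between the core of compound 1 and the core of compound 2 is not broken down here. Compound 3 arises from compound 2 by chloro in place of hydrogen on an aromatic carbon, and that change brought a 1.5-fold lower number from compound 2 to compound 3 (0.19 log units; within the scatter). Compound 4 `O=C(Nc1cc(C(F)(F)F)cc(C(F)(F)F)c1)c1cc(Cl)c(-c2ccccc2)cc1O` arises from compound 1 by the same kind of change, (chloro in place of hydrogen on an aromatic carbon), although here the entering group sits ortho to a phenyl group and para to a hydroxy group rather than ortho to a trifluoromethoxy group. Resting on a 1.5-fold lower number from compound 2 to compound 3 (0.19 log units; within the scatter), a comparably small step is expected, a 1.4-fold lower number from compound 1 to compound 4 (0.15 log units; within the scatter), lying within the scatter. Compound 4 is therefore estimated at 800 nM, with a likely range from 350 nM to 1800 nM.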

Compound 4, half-maximal inhibitory concentration: 790 nM
Estimate against measurement, compound 4: 1.0-fold (0.01 log units) above; the range from low to high includes it.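

In this assay, chloro in place of hydrogen on an aromatic carbon brought a 1.4-fold lower number from compound 1 to compound 4 (0.16 log units; within the scatter). Set beside the earlier step, the change carried over from one core to the other without a detectable difference in size: the same change on two cores in this assay, a 1.5-fold lower number (0.19 log units; within the scatter) from compound 2 to compound 3 and a 1.4-fold lower number (0.16 log units; within the scatter) from compound 1 to compound 4, 1.1-fold (0.03 log units) apart, within the scatter of two such steps. Each step lies within the scatter, so neither shows on its own that chloro changes the number, and two cores do not make a rule for the whole series.

The compounds shown leave open whether a bromo, a methyl, a methoxy or an amine on the same aromatic carbon would give a larger step. They also leave open whether chloro would give a similar step on a core carrying a carboxylic acid in place of the hydroxy group.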